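The compounds below may be only part of what the source reports. "The series", "measured", "known", "first", "only" and "open" are said of these compounds alone.

Measured compounds:
- compound 1 `Cc1n[nH]c2ccc(-c3nc4cnc(N5CCN(C)CC5)cn4c3Nc3ccccc3F)cc12`: 0%
- compound 2 `Cc1n[nH]c2ccc(-c3nc4cnc(N5CCN(C)CC5)cn4c3Nc3ccc(F)cc3Br)cc12`: 82.4%
- compound 3 `Cc1n[nH]c2ccc(-c3nc4cnc(N5CCN(C)CC5)cn4c3Nc3ccc(F)c(Cl)c3)cc12`: 84.1%

In a functional assay on MV4-11 cells (Homo sapiens) for inhibition, with a stated time of 120 h, tested at 10 uM (on this read-out higher numbers stand for more inhibition at the one concentration tested (going by the name of the read-out) and lower numbers for less inhibition), compound 1 gives 0%, the lowest of the three numbers. The two other measured compounds sit far above it: in this assay compound 2 gives 82.4% and compound 3 gives 84.1%, and the gap between those two, a number 1.7 percentage points higher from compound 2 to compound 3 (within the scatter), is within the scatter.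

Compound 4 `Cc1n[nH]c2ccc(-c3nc4cnc(N5CCN(C)CC5)cn4c3Nc3ccc(Cl)cc3Cl)cc12` is a further variation on compound 1 at the same place, the anilino substituent on the shared core: 2,4-dichlorophenyl in place of 2-fluorophenyl on a nitrogen on an aromatic ring. Among the compounds with values here, two measured steps bear on this change, both starting from compound 1 and both replacing the 2-fluorophenyl with a dihalogenated phenyl: a number 82.4 percentage points higher from compound 1 to compound 2 (beyond the scatter) and a number 84.1 percentage points higher from compound 1 to compound 3 (beyond the scatter). Both are large and in the same direction. Within the data shown here, on that basis a large upward step is expected in this assay for compound 4 as well, though the data hold no direct precedent for two chlorines on the phenyl.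

Compound 4 is therefore expected to give about 78% in this assay, within a range from 50% to 95%. That corresponds to an expected step of a number 78 percentage points higher from compound 1 to compound 4 (beyond the scatter).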

Compound 4, a percentage reported as inhibition, at one concentration (the size of the read-out at that concentration, not a potency): 78.8%
Beside the measured number, compound 4's estimate is 0.8 percentage points below it; low and high end bracket the measured number.
By their numbers in this assay, from the lowest: compound 1; then compounds 4, 2 and 3 (each within the scatter of the next).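

In this assay, the step of a number 78.8 percentage points higher from compound 1 to compound 4 (beyond the scatter) shows that the large rise seen with the 2-bromo-4-fluorophenyl and 3-chloro-4-fluorophenyl groups does not depend on keeping a fluorine on the phenyl, since 2,4-dichlorophenyl carries none. The steps of a number 5.3 percentage points lower from compound 3 to compound 4 (within the scatter) and a number 3.6 percentage points lower from compound 2 to compound 4 (within the scatter) both lie within the scatter, so this read-out does not separate the three dihalogenated phenyl groups. Among these four compounds, only the 2-fluorophenyl group stands apart, and no compound goes against that division.

No evidence is available on why this change has so large an effect. As far as these compounds go, it remains open whether a plain phenyl, a 2-chlorophenyl, or a phenyl carrying a methoxy group or an amine would give a number near compound 1 or near compound 4.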